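The source may hold more compounds than are shown below. What is called first, only, known or untested is meant among the compounds shown, and "the series" means these compounds.

Two compounds of a shared core have been examined in a functional assay on Hep 3B2 cells (Homo sapiens) for antiproliferative activity, read by MTT assay, with a stated time of 24 h, tested at 0.14 ug/mL; a higher number here means a stronger effect of the compound at the concentration tested, a lower number a weaker effect. Compound 1 `Cc1ccc2nc(C(=O)Nc3c(F)cc(-c4cccc(F)c4)cc3F)c(C)c(O)c2c1` gives 2.34% in this assay. Compound 2 `Cc1c(C(=O)Nc2c(F)cc(-c3cccc(F)c3)cc2F)nc2ccc(OC(F)(F)F)cc2c1O` gives 2.01% in this assay. The one step between them, a number 0.3 percentage points lower from compound 1 to compound 2 (within the scatter), lies within the scatter, so compound 2 stands together with compound 1 on the numbers shown and cannot be told apart from it.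

Compound 3 `Cc1c(C(=O)Nc2c(F)cc(-c3cccc(F)c3)cc2F)nc2ccc(C(F)(F)F)cc2c1O` has not been measured in this assay. Its change from compound 2 is trifluoromethyl in place of trifluoromethoxy on an aromatic carbon. Within the data shown here, no measured step concerns a trifluoromethyl group, and the only step available, from compound 1 to compound 2, was within the scatter; nothing among the measured compounds points to a movement beyond the scatter. Compound 3 is therefore expected to give 2.5% in this assay, with a range from -6% to 12%. The step this estimate means, a number 0.5 percentage points higher from compound 2 to compound 3 (within the scatter), is expected to stay within the scatter.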

Compound 3, a percentage reported as inhibition, at one concentration (the size of the read-out at that concentration, not a potency): 2.65%
Compound 3: middle estimate off by 0.2 percentage points, on the low side; measured number inside the range.
By their numbers in this assay, from the lowest: compounds 2, 1 and 3 (each within the scatter of the next).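

Replacing the trifluoromethoxy group gives a number 0.6 percentage points higher from compound 2 to compound 3 (within the scatter), and replacing the methyl group gives a number 0.3 percentage points higher from compound 1 to compound 3 (within the scatter), both in this assay. On this aromatic carbon, para to a fused ring, methyl, trifluoromethoxy and trifluoromethyl therefore cannot be told apart, and the loss of the oxygen, with its one hydrogen-bond acceptor, does not move the number beyond the scatter. No information is available to explain why these three groups stand together.

The compounds shown leave open whether an amine or a carboxylic acid on this carbon, each different in kind from the three groups compared, would move the number beyond the scatter. They also leave open whether methyl, trifluoromethoxy and trifluoromethyl would remain indistinguishable at a higher concentration, where the read-out might be larger.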